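Swapping the amino linker for oxygen at the piperidinyl anchor

The compounds below may be only part of what the source reports. "The series", "measured", "known", "first", "only" and "open" are said of these compounds alone.

Compound 1 `Cc1cc(Cl)cc(-c2ccnc3cc(CN4C(=O)C5C(C4=O)C5(C)C)sc23)c1CC1CCCNC1` gives 130 nM in an assay on RKO cells for inhibition of ubiquitin carboxyl-terminal hydrolase 7 (Homo sapiens), read by a luciferase reporter, with a stated time of 18 h; on this read-out higher numbers stand for an effect only at larger amounts of compound and lower numbers for an effect already at smaller amounts.
Compound 2 `Cc1cc(Cl)cc(-c2ccnc3cc(CN4C(=O)C5C(C4=O)C5(C)C)sc23)c1NC1CCCNC1` gives 33 nM in this assay.

Among the compounds with values here, compound 2 holds the lower of the two numbers, with a 3.9-fold lower number from compound 1 to compound 2 (0.60 log units; beyond the scatter) being the only step measured so far. Compound 3 `Cc1cc(Cl)cc(-c2ccnc3cc(CN4C(=O)C5C(C4=O)C5(C)C)sc23)c1OC1CCCNC1` differs from compound 2 by (piperidin-3-yl)oxy in place of (piperidin-3-yl)amino on an aromatic carbon. Within the data shown here, the single measured step shows that the linker at this carbon matters, yet no oxygen-linked analogue has been tested, so the direction is uncertain. A modest rise is expected, a 1.8-fold higher number from compound 2 to compound 3 (0.26 log units; within the scatter), since compound 2 benefited from the change a 3.9-fold lower number from compound 1 to compound 2 (0.60 log units; beyond the scatter) and compound 3 drops one donor. Compound 3 is therefore estimated at 60 nM, between 20 nM and 200 nM.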

Compound 3, half-maximal effective concentration: 250 nM
Compound 3: middle estimate off by 4.2-fold (0.62 log units), on the low side; the whole stated range lies below it.
By their numbers in this assay, from the lowest: compound 2; then compounds 1 and 3 (each within the scatter of the next).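

In this assay, the amino link stands apart from the oxygen link: the change to (piperidin-3-yl)oxy gives a 7.6-fold higher number from compound 2 to compound 3 (0.88 log units; beyond the scatter), so the lower number seen with (piperidin-3-yl)amino does not carry over to oxygen. Against (piperidin-3-yl)methyl, the oxygen link gives a 1.9-fold higher number from compound 1 to compound 3 (0.28 log units; within the scatter), so these two links cannot be told apart here. Nothing available explains why the amino link differs from the other two.

The compounds shown leave open how a methylamino or a thioether link would fall on this aromatic carbon. They also leave open whether the amino link would keep its lower number with a pyrrolidine in place of the piperidine.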